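The compounds below may be only part of what the source reports. "The series", "measured", "known", "first", "only" and "open" are said of these compounds alone.

Measured so far:
Compound 1, `O=C1COCCN1c1ccc(/N=C\c2cn(C(=O)c3ccccc3)c3ccccc23)cc1`: in an ADME assay on BV-2 cells (Mus musculus) for cytotoxicity, read by MTT assay, with a stated time of 48 h (on this read-out higher numbers stand for weaker inhibition and lower numbers for stronger inhibition), compound 1 gives > 100000 nM, which is a limit of the assay.
Compound 2, `O=C1COCCN1c1ccc(/N=C\c2cn(C(=O)c3ccc(Cl)cc3)c3ccccc23)cc1`: in this assay compound 2 gives > 100000 nM, also a limit of the assay.

Among the measured compounds shown here, compound 2 therefore stands only at a limit, and so does its one neighbour, as the limit of > 100000 nM in this assay, at which 2 of the 2 values shown sit, records. For the measured compounds named here, the single measured step, a step that the two limits leave unreadable from compound 1 to compound 2, cannot be read from two limits and gives no direction.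

Compound 3, `O=C1COCCN1c1ccc(/N=C\c2cn(Cc3ccc(F)cc3)c3ccccc23)cc1`, differs from compound 2 by 4-fluorobenzyl in place of (4-chlorophenyl)carbonyl on an aromatic nitrogen. No measured step touches this part of the shared core, so nothing shown speaks for or against a change beyond the scatter. With both neighbours at the limit, the expected step is a number no higher from compound 2 to compound 3 (the limit leaves the size open), that is, none that can be resolved. Compound 3 is estimated at 100000 nM, with a range from 30000 nM to 300000 nM, and a further limit-only result remains the most likely outcome.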

Compound 3, half-maximal inhibitory concentration: > 100000 nM
Compound 3 ended at the assay's limit; the forecaster's own chance of this, stated with the estimate: 70%; the middle value sits exactly at the limit.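

Among the compounds shown here, no step among compound 1, compound 2 and compound 3 can be read in this assay, as all three rest on one limit: the limit of > 100000 nM in this assay, at which 3 of the 3 values shown sit.

The compounds shown leave open how these three rank against one another and whether any change to the shared core's groups gives a value within the assay's range.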